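A few compounds are considered here, and "the series" means these few. Any claim that something is new, unique, unknown or untested is made for them only; others in the source may bear on it.

Compound 1, `COc1cc(-c2nn(-c3ccc(NC(=O)Nc4ccc(Cl)c(Cl)c4)cc3)cc2-c2ccncc2)ccc1Cl`: 3170 nM in a functional assay on UACC-257 cells (Homo sapiens) for antiproliferative activity, read by sulforhodamine B assay, with a stated time of 48 h; a higher number here means a weaker inhibitor, a lower number a stronger inhibitor.
Compound 2, `COc1cc(-c2nn(-c3ccc(NC(=O)Nc4ccc(Cl)c(C(F)(F)F)c4)cc3)cc2-c2ccncc2)ccc1Cl`: 1640 nM.
Compound 3, `O=C(Nc1ccc(-n2cc(-c3ccncc3)c(-c3ccc(Cl)c(O)c3)n2)cc1)Nc1ccc(Cl)c(C(F)(F)F)c1`: 1510 nM.

Compound 3 gives the lowest of the three numbers in this assay, though its gap to compound 2 lies within the scatter; only the gap to compound 1 lies beyond it. Two steps connect these compounds. The step of a 1.9-fold lower number from compound 1 to compound 2 (0.29 log units; within the scatter) swaps one group on the outer ring of the urea. The step of a 1.1-fold lower number from compound 2 to compound 3 (0.04 log units; within the scatter) frees the hydroxyl on the shared core. Both are within the scatter.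

Compound 4, `O=C(Nc1ccc(-n2cc(-c3ccncc3)c(-c3ccc(Cl)c(O)c3)n2)cc1)c1cc(Cl)cc(Cl)c1`, has not yet been measured. It differs from compound 3 by 3,5-dichlorophenyl in place of (4-chloro-3-(trifluoromethyl)phenyl)amino on a carbonyl carbon: the urea becomes an amide, and the outer ring carries two chlorines instead of one chlorine and one trifluoromethyl. Within the data shown here, the step from compound 1 to compound 2 touches the same outer ring and was small; no measured step, however, removes the amino link itself, so the data give no direct guide for that part of the change. A modest rise in number is expected, but it may stay within the scatter. Compound 4 is estimated at 2500 nM, with a range from 700 nM to 9000 nM, which means an expected step of a 1.7-fold higher number from compound 3 to compound 4 (0.22 log units; within the scatter).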

Compound 4, half-maximal inhibitory concentration: 5700 nM
For compound 4 the middle estimate is 2.3-fold (0.36 log units) below the measured one; measured number inside the range.
By their numbers in this assay, from the lowest: compounds 3, 2, 1 and 4 (each within the scatter of the next, the first and the last beyond it).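

In this assay, putting 3,5-dichlorophenyl on the carbonyl carbon in place of (4-chloro-3-(trifluoromethyl)phenyl)amino gives a 3.8-fold higher number from compound 3 to compound 4 (0.58 log units; beyond the scatter), the only step among these compounds that lies beyond the scatter. This shows that the side of the molecule beyond the carbonyl does not tolerate every change: the earlier swap on the outer ring, a 1.9-fold lower number from compound 1 to compound 2 (0.29 log units; within the scatter), stayed within the scatter, whereas the change that turns the urea into an amide and also alters the ring does not. Nothing measured here offers a reason for this loss of activity.

Among these compounds, the single step changes the link and the ring substituents together, so it leaves open how much of the rise belongs to each; an amide carrying the 4-chloro-3-(trifluoromethyl)phenyl ring, or a urea carrying 3,5-dichlorophenyl, would separate the two. Also open, as far as these compounds go, is whether the amino link can be replaced by something other than a direct bond, such as a methylene group or the oxygen atom of a carbamate, while keeping the number near that of compound 3.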